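Aryl piperazine sulfonamides: halogen moved on the phenyl ring

A few compounds are considered here, and "the series" means these few. Any claim that something is new, unique, unknown or untested is made for them only; others in the source may bear on it.

Compound 1 `CCCn1c(=O)[nH]c2nc(-c3ccc(S(=O)(=O)N4CCN(c5cccc(Br)c5)CC4)cc3)[nH]c2c1=O` is the reference of this small set. In an assay on CHO cells for displacement of a labelled ligand from adenosine receptor A3 (Homo sapiens), read by scintillation counting, with a stated time of 45 min, in the presence of a further agent that is not named here (on this read-out higher numbers stand for weaker inhibition and lower numbers for stronger inhibition), compound 1 gives > 1000 nM, which is a limit of the assay and not a number. Compound 2 `CCCn1c(=O)c2[nH]c(-c3ccc(S(=O)(=O)N4CCN(c5ccc(Cl)cc5)CC4)cc3)nc2n(CC)c1=O` gives in this assay > 1000 nM, again only a limit. Compound 3 `CCCn1c(=O)[nH]c2nc(-c3ccc(S(=O)(=O)N4CCN(c5ccccc5)C(C)C4)cc3)[nH]c2c1=O` likewise gives in this assay > 1000 nM, a limit. Compound 1 therefore stands at the limit of > 1000 nM in this assay, at which 3 of the 3 values shown sit, and since no compound shown reaches a measured number, no step between measured compounds can be drawn. Compound 4 `CCCn1c(=O)[nH]c2nc(-c3ccc(S(=O)(=O)N4CCN(c5ccccc5Cl)CC4)cc3)[nH]c2c1=O` carries 2-chlorophenyl in place of 3-bromophenyl on an amine nitrogen in a ring. The step that the limit leaves unreadable from compound 1 to compound 4 is expected to be none beyond the scatter, because all values shown sit at the limit of > 1000 nM in this assay, at which 3 of the 3 values shown sit. Compound 4 is expected to give 3000 nM in this assay, within 800 nM to 20000 nM, most probably reported once more only as a limit.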

Compound 4, inhibition constant: > 1000 nM
Compound 4 gave a limit, no number (the forecaster's own chance of this, stated with the estimate: 75%); the middle value is on the limit's open side.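

No new step can be read between compound 1 and compound 4, as both values are limits: the limit of > 1000 nM in this assay, at which 4 of the 4 values shown sit. The compounds shown leave open how 3-bromophenyl and 2-chlorophenyl rank, and whether any halogenated phenyl here gives a measured number.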